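Cytotoxicity of a furanyl analogue awaits measurement

The compounds below may be only part of what the source reports. "The series", "measured", "known", "first", "only" and "open" are said of these compounds alone.

The series comprises amide-linked acids and esters tested in an ADME assay on HEK293 cells (Homo sapiens) for cytotoxicity, read by CellTiter-Glo and resazurin assay, with a stated time of 72 h; on this read-out higher numbers stand for an effect only at larger amounts of compound and lower numbers for an effect already at smaller amounts. Compound 1 `CC(C)N(Cc1cccc(OCCCCCC(=O)O)c1)C(=O)c1ccc(-c2cccc3ccccc23)cc1` gives in this assay only a limit, > 26000 nM. Compound 2 `CCOc1cccc(-c2ccc(C(=O)N(Cc3cccc(OCCCCCC(=O)O)c3)C(C)C)cc2)c1` likewise gives only a limit, > 20800 nM. Compound 3 `CCOC(=O)CCCCCOc1cccc(CN(C(=O)c2ccc(-c3cccc4ccccc34)cc2)C(C)C)c1` also gives only a limit in this assay, > 26000 nM. The two measured steps are both hidden: the step that the two limits leave unreadable from compound 1 to compound 2 and the step that the two limits leave unreadable from compound 1 to compound 3 run between limits, so their size cannot be read. Compound 3 stands at the limit of > 26000 nM in this assay, at which 2 of the 3 values shown sit. Compound 2 stands at the limit of > 20800 nM in this assay, at which 1 of the 3 values shown sits.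

Compound 4 `CCOC(=O)CCCCCOc1cccc(CN(C(=O)c2ccc(-c3ccco3)cc2)C(C)C)c1` differs from compound 3 in one place: furan-2-yl in place of naphthalen-1-yl on an aromatic carbon. Among the measured compounds shown here, no measured step mirrors this change, so the expectation rests only on the observation that every measured compound in this assay reaches a limit and no number. Compound 4 is therefore expected to give 26000 nM in this assay, within a range from 10000 nM to 80000 nM. The step of a number no higher from compound 3 to compound 4 (the limit leaves the size open) is estimated to stay within the scatter, and the most likely outcome for compound 4 is once more a limit rather than a number.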

Compound 4, half-maximal effective concentration: > 26000 nM
Compound 4: only a limit was reported; the forecaster's own chance of this, stated with the estimate: 85%; the middle value sits exactly at the limit.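

In this assay compound 4 gives > 26000 nM, which is a limit and not a number. Among the compounds shown here, compound 3 also gave only a limit, so no step from compound 3 to compound 4 can be read. The compounds shown leave open at what amount, if any, compounds 1 to 4 would show an effect in this assay.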